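From Fluoro to Chloro on an Aromatic Carbon

The compounds below may be only part of what the source reports. "The series", "measured", "known", "first", "only" and "open" are said of these compounds alone.

Of the compounds shown here, three have so far been measured in an ADME assay on liver (Mesocricetus auratus) for metabolic stability, using microsomes; on this read-out lower numbers stand for slow clearance and higher numbers for fast clearance. Compound 1 `O=C(Nc1cc(-c2ccccn2)n[nH]1)N1CCC(c2cccc(F)c2)CC1` gives 207 mL.min-1.g-1, the higher of the two actual numbers available. Compound 2 `O=C(Nc1cc(-c2ccccn2)n[nH]1)N1CCN(c2ccc(F)cc2)CC1` gives 46.5 mL.min-1.g-1, and its gap to compound 1 lies beyond the usual scatter of repeated measurements. Compound 3 `O=C(NCc1ccccc1)Nc1[nH]nc(-c2ccccn2)c1C1CC1` gives > 400 mL.min-1.g-1, which is a limit of the assay and not a number.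

The unmeasured compound 4 `O=C(Nc1cc(-c2ccccn2)n[nH]1)N1CCC(c2cccc(Cl)c2)CC1` differs from compound 1 in one place: chloro in place of fluoro on an aromatic carbon, meta to a large group, so that 3-fluorophenyl becomes 3-chlorophenyl (chloro in place of fluoro on an aromatic carbon). For the measured compounds named here, no two measured compounds differ in a single place, so there is no measured step to lean on for this swap. Going by the values given here, the expectation therefore starts from compound 1 at 207 mL.min-1.g-1, and only a single substituent changes. In this assay, a step no larger than the scatter is expected, perhaps slightly upward. The estimated step is a 1.2-fold higher number from compound 1 to compound 4 (0.08 log units; within the scatter). A result reported only as a limit remains possible. For compound 4, the expected clearance is 250 mL.min-1.g-1, with an estimated range from 125 mL.min-1.g-1 to 400 mL.min-1.g-1.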

Compound 4, intrinsic clearance in microsomes: 63.5 mL.min-1.g-1
Compound 4: middle estimate off by 3.9-fold (0.60 log units), on the high side; the whole stated range lies above it.
By their numbers in this assay, from the lowest: compounds 2 and 4 (each within the scatter of the next); then compound 1. At a limit, above all of these: compound 3.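

In this assay, for the compounds shown here, exchanging a single atom on the aromatic ring, so that 3-fluorophenyl becomes 3-chlorophenyl, gives a 3.3-fold lower number from compound 1 to compound 4 (0.51 log units; beyond the scatter), and this is the first measured step here in which only one place changes. It shows that this position, on an aromatic carbon of the ring and meta to a large group, is not a silent one for clearance in microsomes: the swap moves the read-out towards slower clearance, even though the groups on each side count one heavy atom, no hydrogen-bond donors or acceptors and no net charge. Nothing measured here accounts for the direction or the size of this step, so it stands as an observation and not as an explanation.

From the compounds shown here alone, what remains open is whether the slower clearance belongs to chloro alone, or whether bromo, methyl or a nitrile at this same place would give a similar result. A single step also cannot tell whether the swap from fluoro to chloro would act in the same way on another aromatic carbon of the ring, or on a compound built on a different core from that of compound 1.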